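Benzoyl swapped for (3-methylphenyl)sulfonyl on the aromatic nitrogen

The compounds below may be only part of what the source reports. "The series", "measured", "known", "first", "only" and "open" are said of these compounds alone.

Measured so far:
compound 1 `O=C(Nc1cccc(/C=C/C(=O)c2nc3ccccc3[nH]2)c1)c1ccccc1`: 11200 nM
compound 2 `Cc1ccc(C(=O)Nc2cccc(/C=C/C(=O)c3nc4ccccc4[nH]3)c2)cc1`: 9690 nM

In a functional assay on MCF7 cells (Homo sapiens) for antiproliferative activity, read by MTT assay, with a stated time of 48 h (a lower number here means a stronger inhibitor, a higher number a weaker inhibitor), compound 1 gives 11200 nM, the higher of the two numbers; compound 2 gives 9690 nM, and the step of a 1.2-fold lower number from compound 1 to compound 2 (0.06 log units; within the scatter) is within the scatter. Compound 3 `Cc1cccc(S(=O)(=O)Nc2cccc(/C=C/C(=O)c3nc4ccccc4[nH]3)c2)c1` is not yet measured. It differs from compound 1 by (3-methylphenyl)sulfonyl in place of benzoyl on a nitrogen on an aromatic ring. Within the data shown here, no measured step touches this position, and the one measured step was within the scatter, so no step beyond the scatter is expected in this assay. Compound 3 is therefore estimated at 10000 nM, in the range 4000 nM to 25000 nM, meaning an expected step of a 1.1-fold lower number from compound 1 to compound 3 (0.05 log units; within the scatter).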

Compound 3, half-maximal inhibitory concentration: 886 nM
Beside the measured number, compound 3's estimate is 11-fold (1.05 log units) above it; the whole stated range lies above it.
By their numbers in this assay, from the lowest: compound 3; then compounds 2 and 1 (each within the scatter of the next).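

In this assay the group on this nitrogen clearly matters: there is a 13-fold lower number from compound 1 to compound 3 (1.10 log units; beyond the scatter) when (3-methylphenyl)sulfonyl replaces benzoyl, and an 11-fold lower number from compound 2 to compound 3 (1.04 log units; beyond the scatter) when it replaces (4-methylphenyl)carbonyl. Each swap changes the link to the ring and the methyl group together, so the gain cannot be assigned to either one alone. No measured evidence here explains the gain.

Still open, going by these compounds, is which part carries it: a plain phenylsulfonyl group would separate the sulfonyl from the methyl. On these data alone, it is also open whether methylsulfonyl, with no ring, or a longer chain on the sulfonyl would keep the gain.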